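The source may report more compounds than this note shows. Statements on the series, on what has been measured and on what is new or still open speak of the compounds shown alone.

Compound 1 `CC1=C(C(=O)OCC(C)C)C(c2cccs2)NC(=O)N1`, compound 2 `CC1=C(C(=O)CC(C)C)C(c2ccoc2)NC(=O)N1` and compound 3 `CCCC(=O)C1=C(C)NC(=O)NC1c1cccs1` have been measured.

In an assay on membranes from CHO cells for displacement of a labelled ligand from adenosine receptor A1 (Homo sapiens), read by scintillation counting, with a stated time of 60 min, tested at 1 uM (on this read-out higher numbers stand for more inhibition at the one concentration tested (going by the name of the read-out) and lower numbers for less inhibition), compound 1 gives 25%, compound 2 gives 23% and compound 3 gives 2%. Compound 3 thus stands lowest of the three, with compound 2 nearest and compound 1 furthest, both beyond the scatter. Compound 4 `CC1=C(C(=O)CC(C)C)C(c2cccs2)NC(=O)N1` differs from compound 3 by methyl in place of hydrogen on a saturated chain carbon bound to two saturated chain carbons. For the measured compounds named here, the one measured step, a number 23 percentage points lower from compound 1 to compound 3 (beyond the scatter), concerns a different change on the carbonyl carbon and does not bear directly on this one, and no measured pair differs by the same change. Compound 2, which carries the isobutylcarbonyl chain, sits well above compound 3, so compound 4 is expected to rise by a number 18 percentage points higher from compound 3 to compound 4 (beyond the scatter). Compound 4 is therefore estimated at 20%, ranging from 5% to 35%.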

Compound 4, a percentage reported as inhibition, at one concentration (the size of the read-out at that concentration, not a potency): 19%
Compound 4: the middle estimate sits 1 percentage points above what was measured; the measured number falls inside the stated range.
By their numbers in this assay, from the lowest: compound 3; then compounds 4, 2 and 1 (each within the scatter of the next).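

In this assay, methyl in place of hydrogen on a saturated chain carbon bound to two saturated chain carbons gives a number 17 percentage points higher from compound 3 to compound 4 (beyond the scatter), so this single branch separates propylcarbonyl from isobutylcarbonyl. Thiophen-2-yl in place of furan-3-yl on a saturated ring carbon gives a number 4 percentage points lower from compound 2 to compound 4 (within the scatter), and the single change on the carbonyl carbon gives a number 6 percentage points lower from compound 1 to compound 4 (within the scatter), so neither change reproduces the size of the branch step. Nothing available here explains the branch step. The compounds shown leave open whether a longer chain or an amine on that carbonyl carbon would hold the number of compound 4 .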